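The source may report more compounds than this note shows. Statements on the series, on what has been measured and on what is new or still open speak of the compounds shown alone.

Compound 3 `CCCCOc1c(OC)c(OC)cc2c1C(=O)[C@]1(OC)C=C[C@H]2N(C(=O)OCC(C)C)N1C(=O)OCC(C)C` gives the lowest number in this set: in an ADME assay on KB cells (Homo sapiens) for cytotoxicity (on this read-out higher numbers stand for an effect only at larger amounts of compound and lower numbers for an effect already at smaller amounts), compound 3 gives 22.1 ug/mL. Its nearest neighbour is compound 2 `CCOC(=O)N1[C@@H]2C=C[C@@](OC)(C(=O)c3c2cc(OC)c(OC)c3OCc2ccc(Cl)cc2)N1C(=O)OCC`, which in this assay gives 99.9 ug/mL, and furthest away lies compound 1 `CCCOc1c(OC)c(OC)cc2c1C(=O)[C@]1(OC)C=C[C@H]2N(C(=O)OCC(C)C)N1C(=O)OCC(C)C`, which in this assay gives 299 ug/mL. Within the data shown here, the only step between compounds differing in one place is a 14-fold lower number from compound 1 to compound 3 (1.13 log units; beyond the scatter), a change from propyl to butyl on the chain attached to the aromatic oxygen.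

Compound 4 `CCOc1c(OC)c(OC)cc2c1C(=O)[C@]1(OC)C=C[C@H]2N(C(=O)OCC(C)C)N1C(=O)OCC(C)C` has not yet been measured in this assay. It differs from compound 3 as follows: hydrogen in place of ethyl on a saturated chain carbon, two bonds along the chain from an oxygen on an aromatic ring. This runs opposite to the step from compound 1 to compound 3, and goes one carbon further, so the measured step is the one that bears on it: it was large, and the expectation is therefore a step in this assay toward a higher number, beyond the scatter, of the order of an 18-fold higher number from compound 3 to compound 4 (1.26 log units; beyond the scatter). On that basis compound 4 is estimated to give 400 ug/mL in this assay, within a range from 150 ug/mL to 1000 ug/mL.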

Compound 4, concentration for half-maximal effect: > 300 ug/mL
Compound 4 gave a limit, no number; the forecaster's own chance of this, stated with the estimate: 15%; the middle value lies beyond the limit too.
By their numbers in this assay, from the lowest: compound 3; then compound 2; then compound 1. At a limit, above all of these: compound 4.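

In this assay compound 4, which carries ethoxy where compound 3 carries butoxy, gives a limit and not a number: the limit of > 300 ug/mL in this assay, at which 1 of the 4 values shown sits.

Even so, shortening the chain from butyl to ethyl can be read as an at least 13-fold higher number from compound 3 to compound 4 (1.13 log units; beyond the scatter), which is beyond the scatter. Across the three alkoxy compounds, the change in chain length now points the same way in both readable steps, as the other is a 14-fold lower number from compound 1 to compound 3 (1.13 log units; beyond the scatter), and none of these compounds goes against that direction. The remaining step is a number no lower from compound 1 to compound 4 (the limit leaves the size open) and its size cannot be read.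

The compounds shown leave open whether a chain longer than butyl would lower the number further or reverse the trend. They also leave open how an amine or a carboxylic acid on the chain would read out here.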